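A few compounds are considered here, and "the series" means these few. Any claim that something is new, unique, unknown or untested is made for them only; others in the source may bear on it.

Compounds measured in a functional assay on HeLa cells (Homo sapiens) for cytotoxicity, read by MTT assay; on this read-out lower numbers stand for stronger inhibition and higher numbers for weaker inhibition:
compound 1, `CC(C)=CC[C@@H](OC(=O)CCO)C1=CC(=O)c2c(O)ccc(O)c2C1=O`, 67600 nM
compound 2, `CC(C)=CC[C@@H](OC[C@H](C)O)C1=CC(=O)c2c(O)ccc(O)c2C1=O`, 40300 nM
compound 3, `CCC(CO[C@H](CC=C(C)C)C1=CC(=O)c2c(O)ccc(O)c2C1=O)OC(C)=O`, 44000 nM

Compound 3 stands second highest of the three numbers, though all three sit close together. Its nearest neighbour is compound 2, with a 1.1-fold higher number from compound 2 to compound 3 (0.04 log units; within the scatter); its furthest is compound 1, with a 1.5-fold lower number from compound 1 to compound 3 (0.19 log units; within the scatter). Both steps are within the scatter, as is a 1.7-fold lower number from compound 1 to compound 2 (0.22 log units; within the scatter), so the three measured compounds show no separation in this assay.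

Compound 4, `CCC(CO[C@H](CC=C(C)C)C1=CC(=O)c2c(O)ccc(O)c2C1=O)OC`, differs from compound 3 as follows: methyl in place of acetyl on an oxygen on a saturated carbon. For the measured compounds named here, the step that bears most directly on this is the one from compound 2 to compound 3, which changed the same oxygen's substituent, 1-acetoxypropyl in place of 1-hydroxyethyl, and gave a 1.1-fold higher number from compound 2 to compound 3 (0.04 log units; within the scatter). The other two steps, likewise at an oxygen on a saturated carbon, were also within the scatter. Nothing in the series therefore points to a step beyond the scatter in this assay for methyl in place of acetyl, in either direction.

Compound 4 is accordingly expected to land near compound 3, with an estimated step of no change at the digits printed from compound 3 to compound 4 (within the scatter), giving an estimate of 44000 nM, in the range 22000 nM to 88000 nM.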

Compound 4, half-maximal inhibitory concentration: 63500 nM
Beside the measured number, compound 4's estimate is 1.4-fold (0.16 log units) below it; measured number inside the range.
By their numbers in this assay, from the lowest: compounds 2, 3, 4 and 1 (each within the scatter of the next).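

Methyl in place of acetyl on this oxygen in this assay (a 1.4-fold higher number from compound 3 to compound 4 (0.16 log units; within the scatter)) shows that the acetyl can be exchanged for the smaller methyl without the pair separating. The 2-methoxybutyl group of compound 4 also stays unseparated from the groups of the other two compounds (a 1.6-fold higher number from compound 2 to compound 4 (0.20 log units; within the scatter); a 1.1-fold lower number from compound 1 to compound 4 (0.03 log units; within the scatter)), so all four substituents on this oxygen, ending in a hydroxyl, an acetoxy or a methoxy, remain within the scatter of one another. No accompanying measurement offers any explanation for this flat result.

The compounds shown leave open whether an amine or a carboxylic acid on this side chain, or a chain longer than the 2-methoxybutyl, would give a step beyond the scatter. They also leave open whether a change to the shared core would do so.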